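Swapping a chlorothiophene amide for a cyclic imide

A few compounds are considered here, and "the series" means these few. Any claim that something is new, unique, unknown or untested is made for them only; others in the source may bear on it.

Compound 1 `CCOC(=O)C1=C(C)NC(C)=C(C(=O)OCC)C1c1ccc(OCC(=O)NNC(=O)c2sccc2Cl)cc1` gives 39.7% in a functional assay on the whole organism (strain Wistar) for inhibition, with Rattus norvegicus as the target, read by paw edema, with stated times of 30 min and 1 h, at a dose of 20 mg/kg; on this read-out lower numbers stand for less inhibition and higher numbers for more inhibition at the one dose given (going by the name of the read-out).
Compound 2 `CCOC(=O)C1=C(C)NC(C)=C(C(=O)OCC)C1c1ccc(OCC(=O)NNC(=O)c2cccs2)cc1` gives 55.1% in this assay.
Compound 3 `CCOC(=O)C1=C(C)NC(C)=C(C(=O)OCC)C1c1ccc(OCC(=O)NNC(=O)c2ccsc2Cl)cc1` gives 42.3% in this assay.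

All three share the same core and differ only in the group carried on the amide-type nitrogen at the end of the side chain. Compound 3 stands second highest of the three: its nearest neighbour is compound 1, and that gap a number 2.6 percentage points higher from compound 1 to compound 3 (within the scatter) lies within the scatter, while compound 2 sits higher, as the step of a number 12.8 percentage points lower from compound 2 to compound 3 (beyond the scatter) shows. Within the data shown here, the only change that clearly moved the read-out was a number 15.4 percentage points higher from compound 1 to compound 2 (beyond the scatter), where hydrogen replaced chloro on an aromatic carbon.

Compound 4 `CCOC(=O)C1=C(C)NC(C)=C(C(=O)OCC)C1c1ccc(OCC(=O)NN2C(=O)c3ccccc3C2=O)cc1` has not yet been measured. It differs from compound 3 by a group of 11 heavy atoms (8 carbon, 1 nitrogen, 2 oxygen; one five-membered non-aromatic ring with 1 hetero atom, one six-membered aromatic ring of carbon only) in place of a group of 9 heavy atoms (5 carbon, 1 nitrogen, 1 oxygen, 1 sulfur, 1 chlorine; one five-membered aromatic ring with 1 hetero atom), on an amide-type nitrogen. Among the measured compounds shown here, none of the measured steps exchanges the whole group on that nitrogen; they only move or remove a chloro on the same five-membered aromatic ring, so they bear on the new step only loosely. With nothing closer to lean on, the expectation for compound 4 is a step of a number 2.7 percentage points higher from compound 3 to compound 4 (within the scatter), that is, no clear move beyond the scatter but with wide uncertainty. Compound 4 is thus estimated at 45%, within a range from 25% to 65%.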

Compound 4, a percentage reported as inhibition, in the whole organism at one dose (the size of the read-out at that dose, not a potency): 42.3%
Estimate against measurement, compound 4: 2.7 percentage points above, and the stated range covers the measured number.
By their numbers in this assay, from the lowest: compounds 1, 3 and 4 (each within the scatter of the next); then compound 2.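

The earlier compounds shown here only moved or removed a chloro on one five-membered aromatic ring, whereas this result replaces the whole group on the amide-type nitrogen with a two-ring group that has no hydrogen-bond donor, and this assay shows no change at the digits printed from compound 3 to compound 4 (within the scatter). The same group compares with the unchlorinated thiophene group as a number 12.8 percentage points lower from compound 2 to compound 4 (beyond the scatter) and with the other chlorinated group as a number 2.6 percentage points higher from compound 1 to compound 4 (within the scatter), so compound 4 joins compound 1 and compound 3 within the scatter, while compound 2 remains clearly separate from all three. Nothing measured here explains why these different groups give such similar read-outs.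

The exchange changes the ring system and removes the hydrogen-bond donor together, so these compounds cannot show which change matters, if either does; a benzoyl group on the same nitrogen, which keeps the amide hydrogen and carries a six-membered aromatic ring of carbon only, would help to separate the two. As far as these compounds go, with a single dose behind each number, it also remains open whether these groups would keep the same order at other doses.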